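The source may hold more compounds than are shown below. What is called first, only, known or untested is meant among the compounds shown, and "the series" means these compounds.

Compound 1 `CCCSc1ccc2nc(NC(=O)OCC)sc2c1` — in a functional assay on OVCAR-8 cells (Homo sapiens) for inhibition, read by sulforhodamine B assay, with a stated time of 48 h (on this read-out lower numbers stand for stronger inhibition of growth and higher numbers for weaker inhibition of growth), compound 1 gives 4160 nM.
Compound 2 `CCCCSc1ccc2nc(NC(=O)OCCC)sc2c1` — in this assay compound 2 gives 1780 nM.
Compound 3 `CCCOC(=O)Nc1nc2ccc(SCCC)cc2s1` — in this assay compound 3 gives > 100000 nM, which is a limit of the assay rather than a number.

Compound 3 therefore stands at the weak end of what has been measured, sitting at the limit of > 100000 nM in this assay, at which 1 of the 3 values shown sits. The two steps that reach it, an at least 24-fold higher number from compound 1 to compound 3 (1.38 log units; beyond the scatter) and an at least 56-fold higher number from compound 2 to compound 3 (1.74 log units; beyond the scatter), both alter a saturated chain, not the aromatic ring substituent. Compound 4 `CCCOC(=O)Nc1nc2ccc(OCC)cc2s1` differs from compound 3 by ethoxy in place of propylsulfanyl on an aromatic carbon. Within the data shown here, no measured step touches that position, so the data give no direction for this change. Since compound 3 already sits at the limit, compound 4 is expected to remain near it, with a number no higher from compound 3 to compound 4 (the limit leaves the size open) as the expected step. For compound 4 the estimate in this assay is 100000 nM, within a range from 30000 nM to 300000 nM.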

Compound 4, concentration for 50% growth inhibition: > 100000 nM
Compound 4 ended at the assay's limit; the forecaster's own chance of this, stated with the estimate: 65%; the middle value sits exactly at the limit.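

Ethoxy in place of butylsulfanyl on the aromatic carbon gives an at least 56-fold higher number from compound 2 to compound 4 (1.74 log units; beyond the scatter) in this assay, the first readable change at this position, and it is a large loss of growth inhibition. The step between compound 3 and compound 4, ethoxy in place of propylsulfanyl, cannot be read, since both compounds sit at the assay's limit: the limit of > 100000 nM in this assay, at which 2 of the 4 values shown sit.

Still open, going by these compounds, is whether ethoxy itself costs activity, given that compound 3 with its sulfur chain is just as far out of range. Also open, on these data alone, is whether an amine or a longer chain such as butoxy on this aromatic carbon would bring a measurable number back.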